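Replacing the cyano group of compound 3

The source may report more compounds than this note shows. Statements on the series, on what has been measured and on what is new or still open speak of the compounds shown alone.

In a functional assay on A549 cells (Homo sapiens) for cytotoxicity, with a stated time of 48 h (on this read-out higher numbers stand for weaker inhibition and lower numbers for stronger inhibition), compound 1 `C[S+]([O-])/C=C/c1cc(=O)c2ccccc2o1` gives 1900 nM, and compound 2 `CCCC(=O)Oc1ccc2oc(/C=C/[S+](C)[O-])cc(=O)c2c1` gives 2200 nM. Compound 3 `C[S+]([O-])/C=C/c1cc(=O)c2cc(C#N)ccc2o1` gives only a limit, > 10000 nM, and no number.

Compound 4 `C[S+]([O-])/C=C/c1cc(=O)c2cc(OC(=O)C(C)(C)C)ccc2o1` differs from compound 3 at a single place, where ((tert-butyl)carbonyl)oxy stands in place of cyano on an aromatic carbon: ((tert-butyl)carbonyl)oxy in place of cyano on an aromatic carbon.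

Among the measured compounds shown here, three measured steps bear on this change. Adding (propylcarbonyl)oxy gave a 1.2-fold higher number from compound 1 to compound 2 (0.06 log units; within the scatter), which lies within the scatter. Adding cyano gave an at least 5.2-fold higher number from compound 1 to compound 3 (0.72 log units; beyond the scatter), which lies beyond it. For the measured compounds named here, the closest precedent is an at least 4.5-fold higher number from compound 2 to compound 3 (0.65 log units; beyond the scatter), where cyano replaced (propylcarbonyl)oxy. Compound 4 swaps cyano for a related group, so that step is expected to run in reverse here, towards stronger inhibition. The expected step is an at least 4.0-fold lower number from compound 3 to compound 4 (0.60 log units; beyond the scatter), which would bring the value back close to that of compound 2 at 2200 nM. For compound 4 the estimated value is 2500 nM, with an expected range of 1000 nM to 7000 nM.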

Compound 4, half-maximal inhibitory concentration: 1600 nM
Compound 4: middle estimate off by 1.6-fold (0.19 log units), on the high side; the measured number falls inside the stated range.
By their numbers in this assay, from the lowest: compounds 4, 1 and 2 (each within the scatter of the next). At a limit, above all of these: compound 3.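

In this assay, among the compounds shown here, ((tert-butyl)carbonyl)oxy at this aromatic carbon restores what cyano lost, an at least 6.2-fold lower number from compound 3 to compound 4 (0.79 log units; beyond the scatter), so a second ester now sits apart from compound 3, the one compound that goes against the flat picture. Exchanging propyl for tert-butyl on the carbonyl carbon leaves the read-out within the scatter, a 1.4-fold lower number from compound 2 to compound 4 (0.14 log units; within the scatter), and the same holds against hydrogen, a 1.2-fold lower number from compound 1 to compound 4 (0.07 log units; within the scatter), so neither ester shown separates from the unsubstituted compound. The first step is only a bound, since compound 3 carries a limit and no number: the limit of > 10000 nM in this assay, at which 1 of the 4 values shown sits.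

The compounds shown leave open whether the carbonyl-oxy link itself matters, which a hydroxyl, a methoxy or an amide at this place would test. They also leave open how a longer chain on the carbonyl carbon would behave.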